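A few compounds are considered here, and "the series" means these few. Any claim that something is new, unique, unknown or untested is made for them only; others in the source may bear on it.

Three members of the series have numbers in a functional assay on the whole organism (strain Swiss albino) with Mus musculus as the target, with a stated time of 4 h; on this read-out lower numbers stand for an effect already at smaller amounts and higher numbers for an effect only at larger amounts of compound. Compound 1 `COc1cc(/C=N/Cc2cccnc2)ccc1O` gives 30 mg/kg there; compound 2 `C/C(=N\Cc1cccnc1)c1ccccc1` gives 30 mg/kg and compound 3 `CC12CCC(C/C1=N/Cc1cccnc1)C2(C)C` gives 100 mg/kg. Compound 1 thus sits level with compound 2 at the digits shown, the two together holding the lowest numbers of the three, while compound 3 stands apart from compound 1 by a gap beyond the usual scatter. Compound 4 `COc1ccc(/C=N/Cc2cccnc2)cc1OC` is not yet measured. It differs from compound 1 in one place: methyl in place of hydrogen on an oxygen on an aromatic ring. Among the compounds with values here, no measured pair in the set shows this change, so its effect is unknown from the data. The expected outcome is no change at the digits printed from compound 1 to compound 4 (within the scatter), a step within the scatter and of no clear direction. Compound 4 is estimated at 30 mg/kg in this assay, within a range from 15 mg/kg to 100 mg/kg.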

Compound 4, minimum effective dose: 30 mg/kg
For compound 4 middle estimate and measured number coincide at the digits printed; low and high end bracket the measured number.
By their numbers in this assay, from the lowest: compounds 1, 2 and 4 (each within the scatter of the next); then compound 3.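

In this assay, within the data shown here, hydroxy to methoxy gives no change at the digits printed from compound 1 to compound 4 (within the scatter), the first reading at this position. Within this pair, the hydrogen on that oxygen is not needed to hold the level of compound 1, and methyl is accepted in its place. No independent measurement bears on this result.

Still open, from the compounds shown here alone, is whether a longer chain such as propyl or benzyl on the same oxygen stays at this level. Also open, going by these compounds, is whether an amine or a carboxylic acid in place of the hydroxy does so.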